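Pyridyl thiosemicarbazide series: shifting the ring methyl

The compounds below may be only part of what the source reports. "The series", "measured", "known", "first", "only" and "open" are said of these compounds alone.

compound 1 `Cc1cccc(/C(N)=N/NC(=S)N2CCN(c3ccccn3)CC2)n1` gives 27.1%
compound 2 `N/C(=N\NC(=S)N1CCCCCC1)c1ccccn1` gives 56%
compound 3 `Cc1cccc(/C(N)=N/NC(=S)N2CCSCC2)n1` gives 20.6%

All three were read in a functional assay on MCF7 cells (Homo sapiens) for cytotoxicity, read by MTT assay, with a stated time of 72 h, tested at 3 uM; a lower number here means less inhibition of growth, a higher number more inhibition of growth at the concentration tested. Compound 1 stands second highest of the three numbers; the nearest is compound 3, whose value lies within the usual scatter of compound 1, while compound 2 lies furthest, higher by a margin beyond the scatter. Among the compounds with values here, no two measured compounds differ in only one place, so no single-change step is available. Compound 4 `Cc1ccnc(/C(N)=N/NC(=S)N2CCN(c3ccccn3)CC2)c1` is the next compound to be measured. It differs from compound 1 by 4-methylpyridin-2-yl in place of 6-methylpyridin-2-yl on a carbon with a double bond to nitrogen; the two hold the same atoms joined differently. Within the data shown here, with no comparable step at hand, the step of a number 0.1 percentage points lower from compound 1 to compound 4 (within the scatter) is expected to stay within the scatter, in no set direction. Compound 4 is estimated at 27%, range 12% to 42%.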

Compound 4, percent growth inhibition at one concentration: 32.8%
Compound 4: the middle estimate sits 5.8 percentage points below what was measured; the measured number falls inside the stated range.
By their numbers in this assay, from the lowest: compounds 3, 1 and 4 (each within the scatter of the next, the first and the last beyond it); then compound 2.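

In this assay the series now has its first single-change step, and a number 5.7 percentage points higher from compound 1 to compound 4 (within the scatter) is what 4-methylpyridin-2-yl in place of 6-methylpyridin-2-yl on the carbon with a double bond to nitrogen amounts to. With the rest of compound 1 unchanged, this shift of the ring methyl gives no readable change in growth inhibition at the concentration tested. No available data offer an explanation for this result.

On these data alone, whether a methoxy or an ethyl group in place of the methyl would read differently stays open. Also open, as far as these compounds go, is whether the same methyl shift gives a comparable result on the core of compound 3.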